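Trimethoxy to dimethoxy on the aryl ketone of the series

The source may hold more compounds than are shown below. What is called first, only, known or untested is meant among the compounds shown, and "the series" means these compounds.

Of the compounds shown here, two have been tested in a functional assay on Huh-7 cells (Homo sapiens) for inhibition, read by sulforhodamine B assay, with a stated time of 72 h; a lower number here means a stronger inhibitor, a higher number a weaker inhibitor. Compound 1 `COc1cc(C(=O)/C=C/c2cn(-c3ccccc3)nc2-c2ccsc2)cc(OC)c1OC` gives 3600 nM. Compound 2 `COc1ccc(C(=O)/C=C/c2cn(-c3ccccc3)nc2-c2ccsc2)c(OC)c1OC` gives 4200 nM in this assay. Among the measured compounds shown here, of the two numbers, compound 2 has the higher one, but the gap to compound 1 lies within the scatter, so the two are read as equal; no step between them can be taken as a finding.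

Compound 3 `COc1ccc(C(=O)/C=C/c2cn(-c3ccccc3)nc2-c2ccsc2)c(OC)c1` is the next compound in line. It differs from compound 2 in one place: hydrogen in place of methoxy on an aromatic carbon, ortho to two methoxy groups and meta to a large group. For the measured compounds named here, no pair of measured compounds shows what such a change does here, so the size of the step rests on expectation alone.

Compound 3 is expected to sit near compound 2 or somewhat above it, with a step of a 1.4-fold higher number from compound 2 to compound 3 (0.15 log units; within the scatter) foreseen. The estimate for compound 3 in this assay is 6000 nM, within a range from 2000 nM to 18000 nM.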

Compound 3, half-maximal inhibitory concentration: 3000 nM
Compound 3: middle estimate off by 2.0-fold (0.30 log units), on the high side, within the range that was stated.
By their numbers in this assay, from the lowest: compounds 3, 1 and 2 (each within the scatter of the next).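

In this assay, hydrogen in place of methoxy on this aromatic carbon, ortho to two methoxy groups and meta to a large group, gives a 1.4-fold lower number from compound 2 to compound 3 (0.15 log units; within the scatter), so compound 2 and compound 3 read as equal. Among the compounds shown here, this is the first one-place step, and it shows that the methoxy group at this carbon is not needed to keep the number in the range held by compound 2. The step gives no sign that this position is sensitive to the change, although a single pair cannot show how far that tolerance extends, and no measurement is available that would explain the result.

Still open, going by these compounds, is whether a different group on this carbon, such as an amine, a carboxylic acid or a longer alkoxy chain, would move the number beyond the scatter. For the compounds shown here, also open is what hydrogen in place of either remaining methoxy group would do, since the single step here speaks only for the one carbon that changed.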